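The compounds below may be only part of what the source reports. "The series", "measured", "known", "first", "only" and "open" are said of these compounds alone.

Working notes on the series. The compounds share one core bearing a neopentyl group, an amino group and an aryl carbonyl. Compound 1 `CC(C)(C)Cc1c(-c2c(F)cccc2F)sc(N)c1C(=O)c1ccc(Cl)cc1` carries a 2,6-difluorophenyl group and a (4-chlorophenyl)carbonyl group; in an assay on CHO cells for displacement of a labelled ligand from adenosine receptor A1 (Homo sapiens), read by scintillation counting, tested at 10 uM (a lower number here means less inhibition, a higher number more inhibition at the concentration tested (going by the name of the read-out)), compound 1 gives 1%. Compound 2 `COc1ccc(-c2sc(N)c(C(=O)c3ccc(C)cc3)c2CC(C)(C)C)cc1` differs from compound 1 in several places, and in this assay compound 2 gives 1%. Compound 1 stands level with compound 2 at the digits shown, the two values falling within the scatter, so no order between them is drawn; both measured compounds sit near the floor of the read-out at the concentration tested.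

Compound 3 `CC(C)(C)Cc1c(-c2cccs2)sc(N)c1C(=O)c1ccc(Cl)cc1` is not yet measured in this assay. Its difference from compound 1 is thiophen-2-yl in place of 2,6-difluorophenyl on an aromatic carbon. For the measured compounds named here, no step between measured compounds is available to gauge this kind of change, and both measured values leave little room for a downward move. The expectation is that the change from compound 1 to compound 3 gives no step beyond the scatter, the estimated step being a number 2 percentage points higher from compound 1 to compound 3 (within the scatter). Compound 3 is accordingly expected to give about 3% in this assay, within a range of 0% to 15%.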

Compound 3, a percentage reported as inhibition, at one concentration (the size of the read-out at that concentration, not a potency): 1%
Compound 3: the middle estimate sits 2 percentage points above what was measured; low and high end bracket the measured number.
By their numbers in this assay, from the lowest: compounds 1, 2 and 3 (each within the scatter of the next).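

In this assay, for the compounds shown here, this is the first step that differs in one place: thiophen-2-yl in place of 2,6-difluorophenyl, on the aromatic carbon next to the ring sulfur, gives no change at the digits printed from compound 1 to compound 3 (within the scatter). With the neopentyl group and the (4-chlorophenyl)carbonyl group held constant, exchanging the six-membered aromatic ring of carbon for a five-membered aromatic ring with one sulfur, and losing both fluorines, does not lift the read-out from the floor at the concentration tested. Nothing at hand bears on why the step has this size.

On these data alone, with all three values near the floor, a lack of response at this position cannot be told apart from a lack of response of the series as a whole, so it remains open whether a carboxylic acid or an aminomethyl group on the aromatic ring here would give measurable inhibition. Also open, as far as these compounds go, is whether a longer chain in place of the neopentyl group, or an amide in place of the amino group, would raise the read-out enough for this exchange to be compared.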